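Swapping the Ethoxy Arm on Compound 1

The compounds below may be only part of what the source reports. "The series", "measured", "known", "first", "only" and "open" are said of these compounds alone.

Compound 1 `CCOC(=O)c1cccc(-c2ccc(OCC)cc2)c1` gives 87%; compound 2 `CCOC(=O)c1ccc(-c2ccc(OCC)cc2)o1` gives 93%; compound 3 `CCOC(=O)c1ccc(-c2ccc(OCC)cc2)[nH]1` gives 44%.

Among these three numbers compound 1 stands second highest. Its nearest neighbour is compound 2, whose number is higher by an amount within the usual scatter, so the two cannot be told apart on this read-out. Compound 3 lies far below compound 1, beyond the scatter. Within the data shown here, no step between measured compounds that differ in one place is given, so these values are only read side by side.

The new compound 4 `CCOC(=O)c1cccc(-c2ccc(CN3CCCCC3)cc2)c1` differs from compound 1 in one place: (piperidin-1-yl)methyl in place of ethoxy on an aromatic carbon. Among the measured compounds shown here, none of the measured compounds carries this group, so nothing measured speaks directly for or against it. In an assay on COS-7 cells for inhibition of patatin-like phospholipase domain-containing protein 2 (Mus musculus), tested at 200 uM (on this read-out higher numbers stand for more inhibition at the one concentration tested (going by the name of the read-out) and lower numbers for less inhibition), the step from compound 1 to compound 4 is expected to be moderate and more likely downward than upward, with a real chance that it stays within the scatter. Compound 4 is therefore estimated at 70%, spanning 35% to 95%, which corresponds to an expected a number 17 percentage points lower from compound 1 to compound 4 (beyond the scatter).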

Compound 4, a percentage reported as inhibition, at one concentration (the size of the read-out at that concentration, not a potency): 68%
Compound 4: middle estimate off by 2 percentage points, on the high side; the measured number falls inside the stated range.
By their numbers in this assay, from the lowest: compound 3; then compound 4; then compounds 1 and 2 (each within the scatter of the next).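

In this assay, (piperidin-1-yl)methyl in place of ethoxy gives a number 19 percentage points lower from compound 1 to compound 4 (beyond the scatter), so the group para to a large group on the core of compound 1 does affect the read-out. The step is modest, and compound 4 still reads 68%, which shows that this position can carry a group with a six-membered non-aromatic ring without losing the read-out altogether. Nothing in the data given explains the size or direction of this step.

This single step exchanges the ethoxy group for a ring-bearing amine in one move, so the contributions of the ring, the nitrogen and the lost oxygen remain unseparated. Also open, on these data alone, is how a morpholine on the same methylene link, a smaller dimethylamine or a longer alkoxy chain would read at this position.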